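A few compounds are considered here, and "the series" means these few. Any claim that something is new, unique, unknown or untested is made for them only; others in the source may bear on it.

Series notes. Compound 1 `Cc1cc(-c2ncccn2)cc(C(=O)NNS(=O)(=O)c2ccccc2)c1F` and compound 2 `Cc1cc(-c2ccccn2)cc(C(=O)NNS(=O)(=O)c2ccccc2)c1F` share one core and differ only in the group that sits on an aromatic carbon. In an ADME assay on microsomes from liver (Homo sapiens) for metabolic stability, read by HPLC, using NADPH, with a stated time of 60 min, tested at 1 uM, in the presence of a further agent that is not named here (a higher number here means faster removal of the compound, a lower number slower removal), compound 1 gives 11 uL/min and compound 2 gives 27 uL/min. For the measured compounds named here, compound 2 stands highest of the two numbers so far in this assay, and the single step on record is a 2.5-fold higher number from compound 1 to compound 2 (0.39 log units; beyond the scatter). Compound 3 `C=CCOc1cc(C)c(F)c(C(=O)NNS(=O)(=O)c2ccccc2)c1` is next for this assay; it differs from compound 2 in this way: allyloxy in place of pyridin-2-yl on an aromatic carbon. Going by the values given here, no measured step covers this exchange. Among the compounds with values here, the one step known, a 2.5-fold higher number from compound 1 to compound 2 (0.39 log units; beyond the scatter), trades one six-membered aromatic ring for another and is only a loose guide for replacing a ring with an open chain. The step from compound 2 is expected to be a 1.3-fold higher number from compound 2 to compound 3 (0.11 log units; within the scatter), with a wide margin on either side. Compound 3 is estimated at 35 uL/min, within a range from 12 uL/min to 100 uL/min.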

Compound 3, intrinsic clearance in a liver preparation (reported as CLH), per the amount of preparation that the assay uses: 73 uL/min
Compound 3: the middle estimate sits 2.1-fold (0.32 log units) below what was measured; measured number inside the range.
By their numbers in this assay, from the lowest: compound 1; then compound 2; then compound 3.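

For the compounds shown here, the earlier step compared only one six-membered aromatic ring with another, whereas this result shows the same aromatic carbon carrying an open chain. In this assay, allyloxy in place of pyridin-2-yl gives a 2.7-fold higher number from compound 2 to compound 3 (0.43 log units; beyond the scatter), and allyloxy in place of pyrimidin-2-yl gives a 6.6-fold higher number from compound 1 to compound 3 (0.82 log units; beyond the scatter), so among these three compounds the open chain stands above both ring-bearing groups, with each step beyond the scatter. Nothing available here explains this rise.

The exchange changes several things at once, so the ring's loss, the chain's oxygen and its double bond remain inseparable. A saturated propoxy chain at this position would bear on the double bond, while a simple methoxy group or a non-aromatic morpholine ring would bear on chain length and on the ring.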